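Moving the methoxyphenyl swap to the amide nitrogen

The source may report more compounds than this note shows. Statements on the series, on what has been measured and on what is new or still open speak of the compounds shown alone.

For the measured compounds named here, compound 1, `O=C(CN1CCN(S(=O)(=O)c2ccccc2F)CC1)Nc1ccccc1F`, gives 8000 nM in an in vitro assay on HEK ts201 cells for negative allosteric modulation of Neuronal acetylcholine receptor; alpha4/beta2 (Homo sapiens), read by fluorescence and calcium flux, with a stated time of 1.5 s (on this read-out lower numbers stand for stronger inhibition and higher numbers for weaker inhibition), the lowest of the three numbers measured so far. Compound 3, `COc1ccc(S(=O)(=O)N2CCN(CC(=O)Nc3ccccc3F)CC2)cc1`, sits closest to it with 13400 nM, while compound 2, `O=C(CN1CCN(S(=O)(=O)c2cccnc2)CC1)Nc1ccccc1F`, is furthest away with 20300 nM. The step of a 1.7-fold higher number from compound 1 to compound 3 (0.22 log units; within the scatter) stays within the scatter, whereas the step of a 2.5-fold higher number from compound 1 to compound 2 (0.40 log units; beyond the scatter) goes beyond it.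

Compound 4, `COc1ccc(NC(=O)CN2CCN(S(=O)(=O)c3ccccc3F)CC2)cc1`, differs from compound 1 in a single place: 4-methoxyphenyl in place of 2-fluorophenyl on an amide-type nitrogen. Among the measured steps, only one involves the same pair of groups, and it occurs on the sulfonyl sulfur rather than on the amide-type nitrogen: a 1.7-fold higher number from compound 1 to compound 3 (0.22 log units; within the scatter), a change that remained within the scatter. Going by the values given here, no measured compound varies the group on the amide-type nitrogen, so the behaviour of that position is not known from these numbers. Taking the sulfonyl-sulfur result as the only available guide, the step of a 1.4-fold higher number from compound 1 to compound 4 (0.14 log units; within the scatter) is expected to be small, leaning if anything toward a higher number. Compound 4 is therefore estimated at 11000 nM in this assay, with a range from 5000 nM to 25000 nM.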

Compound 4, half-maximal inhibitory concentration: 17100 nM
Compound 4: middle estimate off by 1.6-fold (0.19 log units), on the low side; measured number inside the range.
By their numbers in this assay, from the lowest: compounds 1, 3, 4 and 2 (each within the scatter of the next, the first and the last beyond it).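

In this assay the amide-type nitrogen now has a measured step of its own, and it shows that this position responds to the change: 4-methoxyphenyl in place of 2-fluorophenyl gives a 2.1-fold higher number from compound 1 to compound 4 (0.33 log units; beyond the scatter) and so a modest weakening that lies beyond the scatter. For the compounds shown here, the same pair of groups on the sulfonyl sulfur gives a 1.7-fold higher number from compound 1 to compound 3 (0.22 log units; within the scatter) and stays within the scatter, so the two steps point the same way, but only the one on the amide-type nitrogen clears the scatter. No measurement shown here accounts for this step.

With a single swap at this position, the step cannot be divided between the loss of the 2-fluorophenyl group and the arrival of the 4-methoxyphenyl group, and a plain phenyl group on the amide-type nitrogen would be needed to separate the two. From the compounds shown here alone, it also remains open how a group without an aromatic ring, such as cyclohexyl, or a longer link such as benzyl, would read at this position, and whether the step holds with pyridin-3-yl on the sulfonyl sulfur.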